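The source may hold more compounds than are shown below. What is called first, only, known or untested is meant among the compounds shown, and "the series" means these compounds.

Measured so far in a functional assay on MCF7 cells (Homo sapiens) for cytotoxicity, read by MTT assay, with a stated time of 4 days; a lower number here means a stronger inhibitor, a higher number a weaker inhibitor:
- compound 1, `C=C1C[C@]23C[C@@]1(O)CC[C@H]2c1ccc(O)c(C)c1[C@@H]3Cn1cc(-c2ccccn2)nn1`: > 20000 nM (a limit of the assay, not a number)
- compound 2, `C=C1C[C@]23C[C@@]1(O)CC[C@H]2c1ccc(OS(=O)(=O)c2ccc(C)cc2)c(C)c1[C@@H]3Cn1cc(-c2ccc(F)cc2)nn1`: > 20000 nM (a limit of the assay, not a number)

Compound 1 stands at a limit of this assay and nowhere on a scale of numbers. Within the data shown here, compound 2 sits at the same limit, so the limit of > 20000 nM in this assay, at which 2 of the 2 values shown sit, gives no ranking among the two and no measured step exists; of compounds 1 and 2 only this can be said, that both show no inhibition within the tested range.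

Compound 3, `C=C1C[C@]23C[C@@]1(O)CC[C@H]2c1ccc(O)c(C)c1[C@@H]3Cn1cc(-c2ccccc2)nn1`, differs from compound 1 by phenyl in place of pyridin-2-yl on an aromatic carbon. Without any measured step in this assay the expectation can only follow compound 1 at its limit > 20000 nM. The step from compound 1 to compound 3 is expected as a step that the limit leaves unreadable from compound 1 to compound 3, none beyond the scatter. Compound 3 is estimated at 30000 nM, in the range 8000 nM to 100000 nM, most probably reported again only as a limit.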

Compound 3, half-maximal inhibitory concentration: > 20000 nM
Compound 3 gave a limit, no number; the forecaster's own chance of this, stated with the estimate: 80%; the middle value lies beyond the limit too.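

No step can be read between compound 1 and compound 3, which carries phenyl in place of pyridin-2-yl, and both results are limits, not numbers: the limit of > 20000 nM in this assay, at which 3 of the 3 values shown sit.

In this assay the compounds shown leave open how the three rank among themselves and which change to the shared core would give a measured number.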